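Swapping the aryl group on compound 3 for a carboxyphenyl

This account rests on a few compounds, and the source may have more. Where it says the series, first, only, none or still open, it means among the compounds named here.

Measured so far:
- Compound 1, `COc1ccc(C2=Nc3c(C(C)(C)C)nn(CCCO)c3C(=O)NC2)cc1-c1cnn(C)c1`: 2 h
- Compound 2, `COc1ccc(C2=Nc3c(C(C)(C)C)nn(CCCO)c3C(=O)NC2)cc1-c1ccc(F)cc1F`: 2 h
- Compound 3, `COc1ccc(C2=Nc3c(C(C)(C)C)nn(CCCO)c3C(=O)NC2)cc1-c1cnc(N(C)C)cc1C`: 0.7 h

All three share one core and differ only in the aromatic group attached to it. In an ADME assay on microsomes from liver (Homo sapiens) for metabolic stability (on this read-out higher numbers stand for a longer-lived compound and lower numbers for a shorter-lived compound), compound 3 has the lowest number of the three, and both gaps are beyond the scatter: a 2.9-fold lower number from compound 1 to compound 3 (0.46 log units; beyond the scatter) and a 2.9-fold lower number from compound 2 to compound 3 (0.46 log units; beyond the scatter). The two other aryl groups give the same number, no change at the digits printed from compound 1 to compound 2 (within the scatter).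

Compound 4, `COc1ccc(C2=Nc3c(C(C)(C)C)nn(CCCO)c3C(=O)NC2)cc1-c1ccc(C(=O)O)cc1`, makes one further change: 4-carboxyphenyl in place of 6-(dimethylamino)-4-methylpyridin-3-yl on an aromatic carbon. Within the data shown here, no measured step covers a carboxyphenyl, so the bearing steps are the two that lead into compound 3, each of modest size. Those steps show that leaving the dimethylaminomethylpyridinyl behind for either of two other aryl groups went with the higher number, so a return toward that level is the expectation here, an upward step of modest size in this assay, a 2.9-fold higher number from compound 3 to compound 4 (0.46 log units; beyond the scatter). Compound 4 is therefore estimated at 2 h, within a range of 0.8 h to 5 h.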

Compound 4, half-life: 2 h
The estimate for compound 4 equals the measured number at the digits printed; the measured number falls inside the stated range.
By their numbers in this assay, from the lowest: compound 3; then compounds 1, 2 and 4 (each within the scatter of the next).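

In this assay the 4-carboxyphenyl group, placed ortho to a methoxy group, matches the two earlier aryl groups, with no change at the digits printed from compound 1 to compound 4 (within the scatter) and no change at the digits printed from compound 2 to compound 4 (within the scatter) on one side and a 2.9-fold higher number from compound 3 to compound 4 (0.46 log units; beyond the scatter) on the other. Three different groups at this place now share one printed number, which leaves compound 3 as the only one apart, and the earlier compounds had shown this for only two groups, neither of them a carboxylic acid. Nothing shown gives a reason for the lower number of compound 3.

The compounds shown do not separate the dimethylamino group, the ring methyl and the ring nitrogen of compound 3, and a 6-(dimethylamino)pyridin-3-yl group without the methyl would bear on that. Also open, from the compounds shown here alone, is how a 3-carboxyphenyl group or the methyl ester of the acid would compare with compound 4.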